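This account rests on a few compounds, and the source may have more. Where it says the series, first, only, none or still open, it means among the compounds named here.

Measured so far:
- Compound 1, `CC(C)(O)CNc1c(-c2ccccn2)nc2ccccn12`: 171 uL/min
- Compound 2, `Fc1cccc(Nc2c(-c3ccccn3)nc3ccccn23)c1`: 242 uL/min

In an ADME assay on microsomes from liver (Mus musculus) for metabolic stability, read by LC-MS, using NADPH, with a stated time of 60 min, tested at 1 uM, in the presence of a further agent that is not named here (a higher number here means faster removal of the compound, a lower number slower removal), compound 1 gives 171 uL/min and compound 2 gives 242 uL/min. Going by the values given here, compound 2 has the higher of the two numbers, but the only measured step, a 1.4-fold higher number from compound 1 to compound 2 (0.15 log units; within the scatter), lies within the scatter, so the two compounds cannot be told apart on this evidence.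

Compound 3, `COc1ccccc1Nc1c(-c2ccccn2)nc2ccccn12`, has not yet been measured. Its change from compound 2 is 2-methoxyphenyl in place of 3-fluorophenyl on a nitrogen on an aromatic ring. Among the compounds with values here, the one measured step bears only loosely on this: it swapped a 2-hydroxy-2-methylpropyl for a 3-fluorophenyl on the same nitrogen and stayed within the scatter, whereas here one six-membered aromatic ring of carbon only replaces another, with the fluorine leaving and a methoxy group entering. Within the data shown here, nothing among the measured compounds shows the effect of a methoxy group, so no step beyond the scatter is expected in either direction, and the estimate stays close to compound 2.

For compound 3 the expected value in this assay is 260 uL/min, with a range from 130 uL/min to 520 uL/min, which is an expected step of a 1.1-fold higher number from compound 2 to compound 3 (0.03 log units; within the scatter).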

Compound 3, intrinsic clearance in a liver preparation (reported as CLH), per the amount of preparation that the assay uses: 326 uL/min
Compound 3: the middle estimate sits 1.3-fold (0.10 log units) below what was measured; the range from low to high includes it.
By their numbers in this assay, from the lowest: compounds 1, 2 and 3 (each within the scatter of the next).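

In this assay, going by these compounds alone, the new result gives the first reading of a methoxy group at this place: 2-methoxyphenyl in place of 3-fluorophenyl on the nitrogen gives a 1.3-fold higher number from compound 2 to compound 3 (0.13 log units; within the scatter) and so the two compounds cannot be told apart, although the entering group brings a hydrogen-bond acceptor that the leaving group lacks. The larger change of 2-methoxyphenyl in place of 2-hydroxy-2-methylpropyl gives a 1.9-fold higher number from compound 1 to compound 3 (0.28 log units; within the scatter) and this too leaves the pair unresolved, so an open chain and two different substituted aromatic rings on this nitrogen all give numbers that the assay does not separate. Nothing available here explains why these three groups give such similar numbers.

On these data alone, it remains open whether any group on this nitrogen can move the number beyond the scatter, for example a chain ending in an amine or a carboxylic acid, or a longer chain. As far as these compounds go, what a change elsewhere on the shared core would do also stays open, as all three compounds differ only at this one place.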